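Replacing bromo with ethylamino on the side chain

The source may hold more compounds than are shown below. What is called first, only, known or untested is meant among the compounds shown, and "the series" means these compounds.

Measured in a functional assay on A2780 cells (Homo sapiens) for antiproliferative activity, read by MTT assay, with a stated time of 48 h; on this read-out lower numbers stand for stronger inhibition and higher numbers for weaker inhibition:
- compound 1 `COc1ccc(C(=O)c2ccc(OC)c3c2OC(C)(C)C=C3)c(NC(=O)CBr)c1` gives 980 nM
- compound 2 `COc1ccc(C(=O)c2ccc(OC)c3c2C=CC(C)(C)O3)c(NC(=O)CO)c1` gives 420 nM
- compound 3 `COc1ccc(C(=O)c2ccc(OC)c3c2C=CC(C)(C)O3)c(NC(=O)CN)c1` gives 890 nM

Compound 1 sits at the high end of these numbers together with compound 3, the two lying within the scatter of each other. Compound 2 lies lower, beyond the scatter from compound 1.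

The next compound is compound 4 `CCNCC(=O)Nc1cc(OC)ccc1C(=O)c1ccc(OC)c2c1OC(C)(C)C=C2`, which keeps the core of compound 1. The change is ethylamino in place of bromo on a saturated chain carbon bound to a carbonyl carbon.

For the measured compounds named here, one measured step bears on this, and only indirectly: a 2.1-fold higher number from compound 2 to compound 3 (0.33 log units; beyond the scatter), a modest step at the same place but on a different core. Going by the values given here, no measured compound carries ethylamino, and no step starting from bromo exists. Compound 3, the nearest amine, gives 890 nM. No step beyond the scatter is therefore expected in this assay, though the uncertainty runs in both directions.

The estimated step is a 1.1-fold lower number from compound 1 to compound 4 (0.04 log units; within the scatter). Compound 4 is expected at 900 nM, with an estimated range of 300 nM to 2800 nM.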

Compound 4, half-maximal inhibitory concentration: 1980 nM
Estimate against measurement, compound 4: 2.2-fold (0.34 log units) below; low and high end bracket the measured number.
By their numbers in this assay, from the lowest: compound 2; then compounds 3 and 1 (each within the scatter of the next); then compound 4.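

In this assay the side chain on the core of compound 1 now has a measured step of its own, a 2.0-fold higher number from compound 1 to compound 4 (0.31 log units; beyond the scatter) for ethylamino in place of bromo. Beside a 2.1-fold higher number from compound 2 to compound 3 (0.33 log units; beyond the scatter) on a different core, this makes two modest steps to a higher number where a nitrogen group enters on a saturated chain carbon bound to a carbonyl carbon, although the leaving groups differ and two pairs establish no general rule. Nothing available explains the step from bromo to ethylamino.

Open, as far as these compounds go, is whether the ethyl group matters on this core, since the outcome for a plain amino or hydroxy group on the core of compound 1 is unknown. Also open, from the compounds shown here alone, is how a longer chain such as propylamino, or a ring amine such as morpholine, would read on the same carbon.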